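Cytotoxicity notes: cyano for amino on the benzyl ring

This account rests on a few compounds, and the source may have more. Where it says the series, first, only, none or still open, it means among the compounds named here.

The series shares one core, carrying a secondary anilinic linkage to an imidazolylmethyl group and a benzyl substituent whose ring varies. Compound 1 `CNC(=O)c1ccc(NCc2cncn2Cc2ccc(-c3ccccc3)cc2N)cc1-c1ccccc1` is the amide member with a biphenyl-bearing benzyl ring. In a toxicity assay on NIH3T3 cells (Mus musculus) for cytotoxicity, read by resazurin assay (on this read-out higher numbers stand for an effect only at larger amounts of compound and lower numbers for an effect already at smaller amounts), compound 1 gives > 1000 nM, which is a limit of the assay and not a number. Compound 2 `COC(=O)c1ccc(NCc2cncn2Cc2ccc(N)cc2)cc1-c1ccccc1` is the methyl ester with a 4-aminobenzyl group. In this assay compound 2 gives > 10000 nM, again a limit rather than a number. Compound 2 therefore stands at a limit, as does the only other value in the set, so no ordering among the two can be drawn from the numbers shown.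

Compound 3 `COC(=O)c1ccc(NCc2cncn2Cc2ccc(C#N)cc2)cc1-c1ccccc1` is the unmeasured analogue. The change from compound 2 is cyano in place of amino on an aromatic carbon. Within the data shown here, no measured step exists for comparison; given that compound 2 sits at the limit of > 10000 nM in this assay, at which 1 of the 2 values shown sits, no step beyond the scatter is expected in either direction in this assay, and the expected step is a step that the limit leaves unreadable from compound 2 to compound 3. For compound 3 the estimate in this assay is 15000 nM, with a range from 5000 nM to 50000 nM, and most likely reported only as a limit.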

Compound 3, half-maximal effective concentration: > 10000 nM
Compound 3 gave a limit, no number (the forecaster's own chance of this, stated with the estimate: 85%); the middle value lies beyond the limit too.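

Compound 2 and compound 3 both stand at a limit, not a number, in this assay, so no step can be read for cyano in place of amino: the limit of > 10000 nM in this assay, at which 2 of the 3 values shown sit.

The compounds shown leave open whether cyano in place of amino changes the read-out at all, and at what amount either compound would show an effect.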